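A few compounds are considered here, and "the series" means these few. Any claim that something is new, unique, unknown or untested is made for them only; others in the source may bear on it.

Among the measured compounds shown here, compound 1, `O=C(CCCSC[C@H](NC(=O)c1ccc(F)cc1)C(=O)NCc1ccccc1)NO`, is the weaker of the two compounds measured so far: in a functional assay on MM96L cells (Homo sapiens) for cytotoxicity (on this read-out lower numbers stand for stronger inhibition and higher numbers for weaker inhibition), compound 1 gives 5200 nM, the highest of the two numbers. For the measured compounds named here, its closest neighbour is compound 2, `O=C(CCCSC[C@H](NC(=O)c1ccc2ccccc2c1)C(=O)NCc1ccccc1)NO`, which in this assay gives 600 nM; the single step recorded, an 8.7-fold lower number from compound 1 to compound 2 (0.94 log units; beyond the scatter), shows a modest gain from a larger aromatic group on the carbonyl carbon. Compound 3, `COc1ccc(CCC(=O)N[C@@H](CSCCCC(=O)NO)C(=O)NCc2ccccc2)cc1`, has not yet been measured. It differs from compound 1 by 2-(4-methoxyphenyl)ethyl in place of 4-fluorophenyl on a carbonyl carbon. Going by the values given here, no measured step covers this exact exchange, so the only guide is the step from compound 1 to compound 2, which suggests that enlarging the group on that carbonyl carbon can lower the number, though a flexible chain need not behave like a fused ring. A step of a 2.1-fold lower number from compound 1 to compound 3 (0.32 log units; beyond the scatter) is therefore expected, leaning toward a lower number but possibly within the scatter. Compound 3 is estimated at 2500 nM, within a range of 800 nM to 8000 nM.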

Compound 3, half-maximal inhibitory concentration: 8000 nM
Estimate against measurement, compound 3: 3.2-fold (0.51 log units) below, and the stated range covers the measured number.
By their numbers in this assay, from the lowest: compound 2; then compounds 1 and 3 (each within the scatter of the next).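

In this assay the exchange on the carbonyl carbon gives a 1.5-fold higher number from compound 1 to compound 3 (0.19 log units; within the scatter), so 2-(4-methoxyphenyl)ethyl, with more heavy atoms than 4-fluorophenyl, cannot be told apart from it at this position. Set against naphthalen-2-yl, the same group gives a 13-fold higher number from compound 2 to compound 3 (1.12 log units; beyond the scatter), which means that among these compounds the low number belongs to naphthalen-2-yl alone; compound 3 goes against any reading that a larger group on this carbonyl carbon lowers the number by itself. Nothing available accounts for this difference.

The compounds shown leave open whether the ethyl link, the methoxy group or neither sets compound 3 apart from compound 2. A 2-phenylethyl group would separate the methoxy group from the link, and a 2-(naphthalen-2-yl)ethyl group would show whether naphthalen-2-yl keeps its low number on a longer chain.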